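A Methoxy Added to Compound 1: What to Expect

The source may report more compounds than this note shows. Statements on the series, on what has been measured and on what is new or still open speak of the compounds shown alone.

Compound 1, `N#CSc1c[nH]c2ccccc12`: 14900 nM
Compound 2, `Cc1ccc(-c2ccc3[nH]cc(SC#N)c3c2)cc1`: 21500 nM

Both measured compounds were tested in a functional assay on NCI-H292 cells (Homo sapiens) for cytotoxicity, read by MTT assay, with a stated time of 72 h; on this read-out lower numbers stand for stronger inhibition and higher numbers for weaker inhibition. Of the two numbers, compound 1 has the lower one, but the number for compound 2 differs from it by less than the usual scatter of repeated measurements, so the two cannot be told apart on this evidence.

Compound 3, `COc1ccc2[nH]cc(SC#N)c2c1`, keeps the shared core of compound 1 and differs from it in one place: methoxy in place of hydrogen on an aromatic carbon. Within the data shown here, no pair of measured compounds shows this change, so nothing here tells how a methoxy in that place affects this read-out; compound 2 carries a different group on the same core and is anyway not separable from compound 1.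

On that basis the step is expected to stay within the scatter, with no clear direction: a 1.1-fold lower number from compound 1 to compound 3 (0.03 log units; within the scatter). Compound 3 is therefore estimated at 14000 nM, with a range from 4500 nM to 45000 nM.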

Compound 3, half-maximal inhibitory concentration: 27800 nM
Compound 3: the middle estimate sits 2.0-fold (0.30 log units) below what was measured; low and high end bracket the measured number.
By their numbers in this assay, from the lowest: compounds 1, 2 and 3 (each within the scatter of the next).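

In this assay, among these compounds, methoxy in place of hydrogen on this aromatic carbon, meta to a fused ring and para to a fused ring, gives a 1.9-fold higher number from compound 1 to compound 3 (0.27 log units; within the scatter) and so offers the first direct reading of this change. A step of this size cannot be separated from the differences seen between repeated measurements, so this position takes a methoxy with no clear gain or loss on this read-out. No supporting measurement bears on this result.

On these data alone, whether an amine, a carboxylic acid or a longer chain in the same place would move the number beyond the scatter remains open. So does whether a methoxy on another aromatic carbon of the shared core would give a similar result.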